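The source may report more compounds than this note shows. Statements on the series, on what has been measured and on what is new or still open speak of the compounds shown alone.

Within the data shown here, compound 2 `COC(=O)C1CN(Cc2ccc(O)cc2)CC[C@@H]1c1ccc(Cl)cc1` gives 1620 nM in an assay for inhibition of sodium-dependent dopamine transporter (Rattus norvegicus) (a lower number here means a stronger inhibitor, a higher number a weaker inhibitor), the lowest of the two numbers known so far; its nearest neighbour is compound 1 `COC(=O)C1CN(C(C)C)CC[C@@H]1c1ccc(Cl)cc1`, which in this assay gives 6980 nM. Among the measured compounds shown here, the single measured step, a 4.3-fold lower number from compound 1 to compound 2 (0.63 log units; beyond the scatter), shows that exchanging the group on the amine nitrogen in the ring can move the number beyond the scatter. Compound 3 `COC(=O)C1CN(C(C)=O)CC[C@@H]1c1ccc(Cl)cc1` differs from compound 2 by acetyl in place of 4-hydroxybenzyl on an amine nitrogen in a ring. For the measured compounds named here, only that one step bears on this change, and it bears on it through its place alone, since no measured pair brings in acetyl anywhere. The direction is therefore uncertain, but because the move away from isopropyl gave a 4.3-fold lower number from compound 1 to compound 2 (0.63 log units; beyond the scatter), a smaller group entering in the same place is expected to give a higher number, that is a 12-fold higher number from compound 2 to compound 3 (1.09 log units; beyond the scatter). Compound 3 is estimated at 20000 nM in this assay, with a range from 3000 nM to 100000 nM.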

Compound 3, inhibition constant: > 10000 nM
Compound 3: a limit, no number (the forecaster's own chance of this, stated with the estimate: 30%); the middle value does not contradict the limit.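

For compound 3 the result in this assay is a limit of the assay and not a number: the limit of > 10000 nM in this assay, at which 1 of the 3 values shown sits. Replacing 4-hydroxybenzyl with acetyl on this ring nitrogen gives an at least 6.1-fold higher number from compound 2 to compound 3 (0.79 log units; beyond the scatter), so a second exchange at this position moves the result beyond the scatter, and 4-hydroxybenzyl now has the lowest number of the three groups. The comparison with isopropyl is less firm, giving an at least 1.4-fold higher number from compound 1 to compound 3 (0.15 log units; that floor lies within the scatter), so the order of acetyl and isopropyl stays unsettled.

The compounds shown leave open how far above the limit compound 3 lies. They also leave open whether an unsubstituted benzyl group, a methyl group or a longer alkyl chain on this nitrogen would match compound 2, and so whether the aromatic ring or its hydroxyl matters more.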